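The source may hold more compounds than are shown below. What is called first, only, known or untested is meant among the compounds shown, and "the series" means these compounds.

Measured so far in a functional assay on U-87MG ATCC cells (Homo sapiens) for cytotoxicity, read by MTT assay, with a stated time of 48 h; a lower number here means a stronger inhibitor, a higher number a weaker inhibitor:
- compound 1 `C/C(=N\NC(=S)Nc1ccc(Cl)cc1)c1ccccn1` gives 1.7 nM
- compound 2 `C/C(=N\NC(=S)Nc1ccc(F)cc1)c1ccccn1` gives 10 nM

Compound 2 has the higher of the two numbers, which makes it the weaker inhibitor of the pair (a 5.9-fold higher number from compound 1 to compound 2 (0.77 log units; beyond the scatter)). The next compound is compound 3 `C/C(=N\NC(=S)Nc1ccc([N+](=O)[O-])cc1)c1ccccn1`, which carries nitro in place of fluoro on an aromatic carbon, para to a large group (nitro in place of fluoro on an aromatic carbon).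

For the measured compounds named here, only one measured step bears on this change, and it is a modest one at the same place on the shared core: fluoro in place of chloro (a 5.9-fold higher number from compound 1 to compound 2 (0.77 log units; beyond the scatter)). Going by the values given here, one step gives no trend, and no measured compound yet carries nitro. A step of similar modest size is therefore expected in this assay, and its direction is uncertain. A slight lean towards a lower number is taken as a judgement only, as compound 2 at 10 nM is the higher of the two values. The estimated change is small (a 1.7-fold lower number from compound 2 to compound 3 (0.22 log units; within the scatter)). Compound 3 is expected at 6 nM (estimated range 1.5 nM to 30 nM).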

Compound 3, half-maximal inhibitory concentration: 160 nM
Compound 3: the middle estimate sits 27-fold (1.43 log units) below what was measured; the measured number lies above the stated range.
By their numbers in this assay, from the lowest: compound 1; then compound 2; then compound 3.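

In this assay, this aromatic position, para to a large group, tolerates far less change than the halogen pair alone suggested: nitro in place of fluoro gives a large step (a 16-fold higher number from compound 2 to compound 3 (1.20 log units; beyond the scatter)), whereas fluoro in place of chloro gave only a modest one (a 5.9-fold higher number from compound 1 to compound 2 (0.77 log units; beyond the scatter)). Nitro in place of chloro gives the widest step in the series so far (a 94-fold higher number from compound 1 to compound 3 (1.97 log units; beyond the scatter)), so the three groups now stand in a clear order at this place, with chloro lowest, then fluoro, then nitro, and every step between them lies beyond the scatter. Nothing available accounts for the size of the nitro step.

For the compounds shown here, with only three groups at one place, the order gives no rule, and it remains open where an amine, a methoxy group or a methyl group would fall relative to chloro and nitro, and whether bromo would stay close to chloro. On these data alone, it is also open whether the same order of the three groups would hold in any other cell line.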